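The source may hold more compounds than are shown below. What is called first, only, known or untested is meant among the compounds shown, and "the series" means these compounds.

Among the compounds with values here, compound 2, `CCCCCCCCS(=O)(=O)Nc1cc(-c2ccccc2F)ccc1C(=O)O`, stands highest of the two numbers measured so far in an assay on mitochondria (strain BALB/c) for inhibition of glycerol-3-phosphate acyltransferase 1, mitochondrial (Mus musculus), read by scintillation counting, with a stated time of 10 min; a higher number here means a weaker inhibitor, a lower number a stronger inhibitor: compound 2 gives 47200 nM, while compound 1, `CCCCCCCCS(=O)(=O)Nc1cc(-c2ccc(OC)cc2)ccc1C(=O)O`, gives 13300 nM. Within the data shown here, the single measured step runs between these two: a 3.5-fold higher number from compound 1 to compound 2 (0.55 log units; beyond the scatter). It concerns only the substituent on the pendant ring, not the link to the core.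

Compound 3, `CCCCCCCCS(=O)(=O)Nc1cc(/C=C/c2ccccc2)ccc1C(=O)O`, is the next compound. Its change from compound 2: 2-phenylethenyl in place of 2-fluorophenyl on an aromatic carbon. Among the measured compounds shown here, no measured step exchanges the whole pendant aryl group for an ethenyl-linked one, so the step from compound 1 to compound 2 bears on this change only indirectly, and its size was modest. The read-out for compound 3 in this assay is therefore expected to stay within a modest step of compound 2 as well, with a slight lean toward a lower number, since compound 1 with 4-methoxyphenyl gives 13300 nM. The expected step is a 2.4-fold lower number from compound 2 to compound 3 (0.37 log units; beyond the scatter). Compound 3 is estimated at 20000 nM, in the range 6000 nM to 70000 nM. The next figure will show whether this holds.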

Compound 3, half-maximal inhibitory concentration: 38000 nM
Compound 3: middle estimate off by 1.9-fold (0.28 log units), on the low side; low and high end bracket the measured number.
By their numbers in this assay, from the lowest: compound 1; then compounds 3 and 2 (each within the scatter of the next).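

In this assay, the exchange of 2-fluorophenyl for 2-phenylethenyl on this aromatic carbon, para to the carboxy group, gives a 1.2-fold lower number from compound 2 to compound 3 (0.09 log units; within the scatter). This change removes the fluorine and adds a double bond outside aromatic rings, yet the two compounds cannot be told apart in this assay. Against 4-methoxyphenyl, the same 2-phenylethenyl group gives a 2.9-fold higher number from compound 1 to compound 3 (0.46 log units; beyond the scatter), so compound 1 now has a lower number than both other compounds by more than the scatter, and the series separates into 4-methoxyphenyl on one side and the two groups without a methoxy on the other. No measurement at hand offers an explanation for this separation.

Within the data shown here, with only three compounds, the separation of compound 1 cannot be assigned to the methoxy group itself or to its placement at the 4-position of the ring, and unsubstituted phenyl, 4-fluorophenyl and 2-methoxyphenyl at this carbon would be the direct comparisons. The series also leaves open whether 2-phenylethenyl tolerates a methoxy or an amine on its own ring, and whether a saturated 2-phenylethyl group reads the same as the ethenyl-linked one.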